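A few compounds are considered here, and "the series" means these few. Any claim that something is new, unique, unknown or untested is made for them only; others in the source may bear on it.

Compound 1 (`CCOC(=O)C12C(=O)OCC=C1COC2c1cccc(Cl)c1`) was tested in a functional assay on QGY cells (Homo sapiens) for cytotoxicity, read by MTT assay; a lower number here means a stronger inhibitor, a higher number a weaker inhibitor. There compound 1 gives > 1000000 nM, which is a limit of the assay rather than a measured number. Among the measured compounds shown here, its only measured neighbour is compound 2 (`CCOC(=O)C12C(=O)OCC=C1COC2c1ccc(Cl)c(Cl)c1`), which carries a chloro in place of hydrogen on an aromatic carbon. In this assay compound 2 likewise gives > 1000000 nM, again a limit. The step that the two limits leave unreadable from compound 1 to compound 2 therefore cannot be read; both values rest at the limit of > 1000000 nM in this assay, at which 2 of the 2 values shown sit. Compound 3 (`CCOC(=O)C12C(=O)OCC=C1COC2c1ccco1`) differs from compound 1 by furan-2-yl in place of 3-chlorophenyl on a saturated ring carbon. For the measured compounds named here, no measured step tells what such an exchange does in this assay; the only step at hand, a step that the two limits leave unreadable from compound 1 to compound 2, is itself unreadable. So nothing argues for a move beyond the scatter, and compound 3 is expected to show a step of a number no higher from compound 1 to compound 3 (the limit leaves the size open). The estimate for compound 3 in this assay is 1000000 nM, with a range from 300000 nM to 3000000 nM, and most likely it will again be reported only as a limit.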

Compound 3, half-maximal inhibitory concentration: > 1000000 nM
Compound 3 was reported as a limit (the forecaster's own chance of this, stated with the estimate: 85%); the middle value sits exactly at the limit.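

In this assay compound 3 gives > 1000000 nM, again a limit of the assay and not a number. Among the compounds shown here, no step can therefore be read between compound 1 and compound 3, and all the values rest at one limit: the limit of > 1000000 nM in this assay, at which 3 of the 3 values shown sit. The compounds shown leave open whether any change to the shared core would give a measurable value in this assay.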